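From chlorine to bromine in a small amide series

The source may report more compounds than this note shows. Statements on the series, on what has been measured and on what is new or still open speak of the compounds shown alone.

Going by the values given here, three amides sharing one core have numbers so far. In a functional assay on KG-1 cells (Homo sapiens) for cytotoxicity, read by luminescence and CellTiter-Glo, with a stated time of 3 days (on this read-out lower numbers stand for stronger inhibition and higher numbers for weaker inhibition), compound 1 `O=C(Nc1cc(C(F)(F)F)cc(C(F)(F)F)c1)c1cc(Br)c(-c2ccccc2)cc1O` gives 300 nM, compound 2 `O=C(Nc1cc(C(F)(F)F)cc(C(F)(F)F)c1)c1cc(F)ccc1O` gives 470 nM, and compound 3 `O=C(Nc1cc(C(F)(F)F)cc(C(F)(F)F)c1)c1ccc(Cl)cc1O` gives 620 nM. Compound 3 therefore stands within the scatter of compound 2, while its number lies beyond the scatter above that of compound 1.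

Compound 4 `O=C(Nc1cc(C(F)(F)F)cc(C(F)(F)F)c1)c1cc(Br)ccc1O` has not yet been measured. It differs from compound 3 in one place: 5-bromo-2-hydroxyphenyl in place of 4-chloro-2-hydroxyphenyl on a carbonyl carbon. Among the compounds with values here, the only measured step of this kind, a swap of one halogen-bearing group for another on the same carbonyl carbon, is a 1.3-fold higher number from compound 2 to compound 3 (0.12 log units; within the scatter). Compound 1 also carries bromine, but it holds a further substituent, so it offers only indirect guidance. With that single small step as the precedent, no shift beyond the scatter is expected in this assay. The expected step is a 1.4-fold lower number from compound 3 to compound 4 (0.14 log units; within the scatter). For compound 4, the estimated value is 450 nM, with an expected range of 220 nM to 900 nM.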

Compound 4, half-maximal inhibitory concentration: 300 nM
For compound 4 the middle estimate is 1.5-fold (0.18 log units) above the measured one; low and high end bracket the measured number.
By their numbers in this assay, from the lowest: compounds 1, 4, 2 and 3 (each within the scatter of the next, the first and the last beyond it).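

Replacing 4-chloro-2-hydroxyphenyl with 5-bromo-2-hydroxyphenyl on the carbonyl carbon gives a 2.1-fold lower number from compound 3 to compound 4 (0.32 log units; beyond the scatter) in this assay, the first modest step beyond the scatter among these amides, though the halogen and its numbered place on the ring change together. Bromo in place of fluoro on an aromatic carbon gives only a 1.6-fold lower number from compound 2 to compound 4 (0.19 log units; within the scatter) and so stays within the scatter, which means the halogen swap at that one place is not resolved in this assay. Hydrogen in place of phenyl on an aromatic carbon gives no change at the digits printed from compound 1 to compound 4 (within the scatter) and shows that compound 1 does not depend on its phenyl group for its number here.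

Going by these compounds, whether an amine or a carboxylic acid in place of the bromo would keep this level of activity remains open. Nothing shown here explains why any of these steps has the size it does.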